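A few compounds are considered here, and "the series" means these few. Any claim that something is new, unique, unknown or untested is made for them only; others in the source may bear on it.

In a functional assay on the whole organism (strain Sprague-Dawley) for inhibition, with Rattus norvegicus as the target (on this read-out higher numbers stand for an effect only at larger amounts of compound and lower numbers for an effect already at smaller amounts), two compounds have been measured so far. Compound 1, `COc1cccc2cc(C(=O)O)cnc12`, gives 150 mg/kg in this assay. Compound 2, `O=c1c(-c2nn[nH]n2)c[nH]c2c(F)ccc(F)c12`, gives 10 mg/kg in this assay. Of the two numbers, compound 2 holds the lower one, and the gap to its only companion, compound 1, lies beyond the usual scatter of such measurements, so compound 2 is the more potent of the pair on this read-out.

Compound 3, `O=c1c(-c2nn[nH]n2)c[nH]c2c(F)cccc12`, has not yet been measured in this assay. It differs from compound 2 in one place: hydrogen in place of fluoro on an aromatic carbon. The difference is a single fluorine atom of the shared core; the rest of the structure is unchanged.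

For the measured compounds named here, no measured pair differing in one place is available, so the size of such a step cannot be read from the numbers at hand. The change is small, and the step expected in this assay is a 1.5-fold higher number from compound 2 to compound 3 (0.18 log units; within the scatter), a modest rise that may well stay within the scatter. The value expected for compound 3 in this assay is 15 mg/kg, with a range from 5 mg/kg to 50 mg/kg.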

Compound 3, minimum effective dose: 10 mg/kg
Compound 3: middle estimate off by 1.5-fold (0.18 log units), on the high side, and the stated range covers the measured number.
By their numbers in this assay, from the lowest: compounds 2 and 3 (each within the scatter of the next); then compound 1.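

Exchanging the fluoro group for hydrogen on this aromatic carbon, which sits ortho to a fused ring, meta to a fused ring and para to a fluoro group, gives no change at the digits printed from compound 2 to compound 3 (within the scatter) in this assay. For the compounds shown here, this is the first pair that differs in one place, and it shows that the fluoro group at this position is not needed for the number to stay where it stands, at least with the other fluoro group of compound 3 in place. The earlier compounds could not show this, since they differ in more than one place and gave no step from which the weight of this single atom could be read, and nothing at hand gives a reason for the outcome.

The compounds shown leave open whether a chloro group, a trifluoromethyl group or an amine on this same carbon would also leave the number unchanged, or would shift it beyond the scatter. They also leave open what happens when the other fluoro group on the shared core gives way to hydrogen, so the part played by that atom cannot yet be judged.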